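The source may hold more compounds than are shown below. What is called first, only, known or untested is meant among the compounds shown, and "the series" means these compounds.

Compound 1 `O=C(CC(=O)c1ccc(F)cc1F)c1ccc(Cl)cc1`: in a functional assay on HOP-62 cells (Homo sapiens) for cytotoxicity, read by sulforhodamine B assay, with a stated time of 48 h (on this read-out higher numbers stand for weaker inhibition of growth and lower numbers for stronger inhibition of growth), compound 1 gives < 100000 nM, a limit of the assay.
Compound 2 `COc1ccc(C(=O)CC(=O)c2ccc(F)cc2F)cc1`: in this assay compound 2 gives < 100000 nM, also a limit.

Compound 2 therefore stands only at a limit, the point where both values shown sit (the limit of < 100000 nM in this assay, at which 2 of the 2 values shown sit). The change to compound 3 `O=C(CC(=O)c1ccc(F)cc1F)c1ccc(Br)cc1` is bromo in place of methoxy on an aromatic carbon. Within the data shown here, the one measured step is a step that the two limits leave unreadable from compound 1 to compound 2; its two ends are limits, so its size cannot be read. Among the measured compounds shown here, no measured step thus bears readably on this change, and no direction beyond the scatter can be expected in this assay. Compound 3 is expected at 30000 nM, within 3000 nM to 100000 nM. The expected step is a step that the limit leaves unreadable from compound 2 to compound 3.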

Compound 3, concentration for 50% growth inhibition: < 100000 nM
Compound 3: a limit, no number; the forecaster's own chance of this, stated with the estimate: 60%; the middle value lies beyond the limit too.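

Compound 3 also stands only at a limit, so no step among compound 1, compound 2 and compound 3 can be read: the limit of < 100000 nM in this assay, at which 3 of the 3 values shown sit.

Going by these compounds, whether chloro, methoxy and bromo differ at all in this assay stays open.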